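The source may report more compounds than this note shows. Statements on the series, on what has been measured and on what is new or still open speak of the compounds shown alone.

Three related compounds have been tested in an ADME assay on RAW264.7 cells (Mus musculus) for inhibition, read by trypan blue exclusion, with a stated time of 48 h; a higher number here means a weaker inhibitor of growth, a lower number a stronger inhibitor of growth. Compound 1, `COC(=O)/C=C/c1cccc(O)c1`, gives 850000 nM in this assay. Compound 2, `CC(C)=CCOc1ccccc1/C=C/C(=O)O`, gives 1680000 nM. Compound 3, `COC(=O)/C=C/c1ccc(OC/C=C(\C)CCC=C(C)C)cc1`, gives 159000 nM, the lowest of the three numbers, and therefore the strongest inhibitor of growth among them: its gaps to compound 1 and to compound 2 both lie beyond the usual scatter of such measurements, with compound 2 the furthest away.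

The next compound to be looked at is compound 4, `CC(C)=CCC/C(C)=C/COc1ccc(/C=C/C(=O)O)cc1`. It keeps the long chain-bearing side of compound 3 and changes only the end that carries the carbonyl group: hydrogen in place of methyl on an oxygen next to a carbonyl group. Among the measured compounds shown here, no pair of already measured compounds differs in this single way, so there is no measured step to lean on. Compound 1 is a methyl ester and compound 2 is a carboxylic acid, but they differ in other places too, so their two values cannot be read as the effect of this change alone.

On this thin basis the expectation for compound 4 is a modestly weaker inhibitor of growth than compound 3, a step of a 2.5-fold higher number from compound 3 to compound 4 (0.40 log units; beyond the scatter) in this assay, with the estimate for compound 4 placed at 400000 nM and a range from 120000 nM to 1500000 nM.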

Compound 4, concentration for 50% growth inhibition: 210000 nM
For compound 4 the middle estimate is 1.9-fold (0.28 log units) above the measured one, and the stated range covers the measured number.
By their numbers in this assay, from the lowest: compounds 3 and 4 (each within the scatter of the next); then compounds 1 and 2 (each within the scatter of the next).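

Among the compounds shown here, replacing methyl with hydrogen on an oxygen next to a carbonyl group turns the methoxycarbonyl group of compound 3 into the carboxy group of compound 4, and this single change gives a 1.3-fold higher number from compound 3 to compound 4 (0.12 log units; within the scatter) in this assay as the first clean comparison of this kind. The earlier compounds shown here could not isolate this change, but this pair shows that, with the rest of the structure held constant, the methyl ester and the carboxylic acid cannot be told apart in this assay. No supporting measurement is available to explain why these two compounds read alike.

This single pair leaves open whether the same insensitivity extends to other groups at this end of the molecule, such as an ethyl ester, a primary amide or a hydroxamic acid, any of which would test the place more widely than a swap of methyl for hydrogen. It also leaves open whether the methyl-to-hydrogen change would read the same way on a compound carrying a shorter or longer chain on the other side, or in a different assay.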